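Moving the methoxy groups on compound 2

The source may hold more compounds than are shown below. What is called first, only, known or untested is meant among the compounds shown, and "the series" means these compounds.

Compound 1 `COc1cc(-c2cccc3nc(-c4cccc(N)c4)oc23)cc(OC)c1OC` gives 2200 nM
Compound 2 `COc1ccc(-c2nc3c(-c4cc(OC)c(OC)c(OC)c4)cccc3o2)cc1OC` gives > 25000 nM (a limit)

Both values come from a functional assay on U-251 cells (Homo sapiens) for antiproliferative activity, read by MTT assay, with a stated time of 48 h (on this read-out lower numbers stand for stronger inhibition and higher numbers for weaker inhibition), and only compound 1 has a true number there. Compound 2 reaches only a limit and sits at the limit of > 25000 nM in this assay, at which 1 of the 2 values shown sits, in the series. Compound 3 `COc1cc(OC)cc(-c2nc3c(-c4cc(OC)c(OC)c(OC)c4)cccc3o2)c1` is unmeasured and has the same atoms as compound 2, joined differently, with 3,5-dimethoxyphenyl in place of 3,4-dimethoxyphenyl on an aromatic carbon on an aromatic carbon. Within the data shown here, no measured step guides this change, so nothing beyond the scatter is expected in either direction, and the estimated step is a number no higher from compound 2 to compound 3 (the limit leaves the size open) in this assay for now. For compound 3 the expected value is 25000 nM within an estimated range of 8000 nM to 60000 nM and a further limit is quite possible.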

Compound 3, half-maximal inhibitory concentration: > 25000 nM
Compound 3 gave a limit, no number; the forecaster's own chance of this, stated with the estimate: 65%; the middle value sits exactly at the limit.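

Compound 2 and compound 3 both give only a limit, not a number, so no step can be read between them: the limit of > 25000 nM in this assay, at which 2 of the 3 values shown sit. The compounds shown leave open how 3,4-dimethoxyphenyl and 3,5-dimethoxyphenyl compare on the shared core.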